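Chloroanilide bis-thioesters: KB cell growth inhibition notes

The compounds below may be only part of what the source reports. "The series", "measured", "known", "first", "only" and "open" are said of these compounds alone.

Measured compounds:
compound 1 `CC(=O)SCCC(CCCCC(=O)Nc1ccccc1Cl)SC(C)=O`: 8.21%
compound 2 `CC(=O)SCCC(CCCCC(=O)Nc1cccc(Cl)c1)SC(C)=O`: 0.04%
compound 3 `O=C(CCCCC(CCSC(=O)c1ccccc1)SC(=O)c1ccccc1)Nc1ccccc1Cl`: 3.05%

All three values come from a functional assay on KB cells (Homo sapiens) for inhibition, read by MTT assay, with a stated time of 24 h, tested at 1 ug/mL (a higher number here means more inhibition of growth at the concentration tested, a lower number less inhibition of growth), and sit near the bottom of the scale. Compound 1 gives 8.21% and compound 2 gives 0.04%; the change between them is 3-chlorophenyl in place of 2-chlorophenyl on an amide-type nitrogen and the step is a number 8.2 percentage points lower from compound 1 to compound 2 (within the scatter). The difference between the core of compound 1 and the core of compound 3 is not broken down here. Compound 3 gives 3.05% in this assay.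

Compound 4 `O=C(CCCCC(CCSC(=O)c1ccccc1)SC(=O)c1ccccc1)Nc1cccc(Cl)c1` is not yet measured. It differs from compound 3 by 3-chlorophenyl in place of 2-chlorophenyl on an amide-type nitrogen, the same change as from compound 1 to compound 2. The step is expected to be a number 2.1 percentage points lower from compound 3 to compound 4 (within the scatter) in this assay, resting on the earlier step of a number 8.2 percentage points lower from compound 1 to compound 2 (within the scatter), which lies within the scatter. Compound 4 is therefore estimated at 1%, with a range from 0% to 10%.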

Compound 4, percent growth inhibition at one concentration: 12.7%
Beside the measured number, compound 4's estimate is 11.7 percentage points below it, outside the stated range (above it).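

In this assay, 3-chlorophenyl in place of 2-chlorophenyl on an amide-type nitrogen gives a number 9.7 percentage points higher from compound 3 to compound 4 (within the scatter), and the change does not carry over in size or direction from one core to the other: the same change on two cores in this assay, a number 8.2 percentage points lower (within the scatter) from compound 1 to compound 2 and a number 9.7 percentage points higher (within the scatter) from compound 3 to compound 4, 17.8 percentage points apart, beyond the scatter of two such steps. Each step alone lies within the scatter, so neither shows a preference between the two chlorophenyl groups on its own core. The pair shows that the step on one core was a poor guide to the step on the other, but it sets no rule for the series and gives no cause.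

On these data alone, whether the same holds for an unsubstituted phenyl on the amide-type nitrogen stays open. So does the effect of free thiols in place of the thioesters, or of a longer chain.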